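The source may report more compounds than this note shows. Statements on the series, on what has been measured and on what is new or still open speak of the compounds shown alone.

Working notes on the series. Of the compounds shown here, three sharing the same core have been measured in an assay on CHO cells for displacement of a labelled ligand from Melanocortin receptor 3 (Homo sapiens); on this read-out higher numbers stand for weaker inhibition and lower numbers for stronger inhibition. Compound 1 `CC(=O)N(CC(C1CCCCC1)N1CCN(C(=O)[C@@H]2CN(C(C)(C)C)C[C@H]2c2ccc(F)cc2F)CC1)C(C)C` gives 6500 nM. Compound 2 `CC(C)N(CC(C1CCCCC1)N1CCN(C(=O)[C@@H]2CN(C(C)(C)C)C[C@H]2c2ccc(F)cc2F)CC1)S(C)(=O)=O` gives 3600 nM, and the step of a 1.8-fold lower number from compound 1 to compound 2 (0.26 log units; within the scatter) is within the scatter. Compound 3 `CC(C)N(CC(C1CCCCC1)N1CCN(C(=O)[C@@H]2CN(C(C)(C)C)C[C@H]2c2ccc(F)cc2F)CC1)C(=O)c1cccnn1` gives 770 nM, the lowest of the three numbers; the steps of an 8.4-fold lower number from compound 1 to compound 3 (0.93 log units; beyond the scatter) and a 4.7-fold lower number from compound 2 to compound 3 (0.67 log units; beyond the scatter) are both beyond the scatter, so compound 3 stands apart from the other two.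

Compound 4 `CC(C)N(CC(C1CCCCC1)N1CCN(C(=O)[C@@H]2CN(C(C)(C)C)C[C@H]2c2ccc(F)cc2F)CC1)C(=O)c1cnn(C(C)C)c1` has not yet been measured. It differs from compound 3 in one place: 1-isopropyl-1H-pyrazol-4-yl in place of pyridazin-3-yl on a carbonyl carbon. The measured steps that bear on this are those leading to compound 3, which show that an aromatic ring on the carbonyl carbon gave a modestly lower number than methyl or methylsulfonyl. For the measured compounds named here, no measured pair exchanges one aromatic ring for another on that carbonyl carbon, so the size of the step from compound 3 to compound 4 in this assay cannot be read from a comparable step. The expectation is that compound 4 keeps an aromatic ring in that position and lands near compound 3, with a step of a 1.2-fold higher number from compound 3 to compound 4 (0.07 log units; within the scatter) that is expected to fall within the scatter. The estimate for compound 4 is therefore 900 nM, with a range from 300 nM to 2700 nM.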

Compound 4, half-maximal inhibitory concentration: 870 nM
Beside the measured number, compound 4's estimate is 1.0-fold (0.01 log units) above it; the range from low to high includes it.
By their numbers in this assay, from the lowest: compounds 3 and 4 (each within the scatter of the next); then compounds 2 and 1 (each within the scatter of the next).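

In this assay, the exchange on the carbonyl carbon gives a 1.1-fold higher number from compound 3 to compound 4 (0.05 log units; within the scatter), so a five-membered aromatic ring bearing isopropyl, with 8 heavy atoms, and a six-membered aromatic ring, with 6 heavy atoms, are not told apart at this position. The lower number first seen with pyridazin-3-yl is therefore not confined to that ring, as the second aromatic ring also gives a 7.5-fold lower number from compound 1 to compound 4 (0.87 log units; beyond the scatter) and a 4.1-fold lower number from compound 2 to compound 4 (0.62 log units; beyond the scatter), both beyond the scatter. The series offers no measurement that accounts for the size of these steps or for the closeness of the two aromatic groups.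

The compounds shown leave open whether the hetero atoms in the ring contribute at all, since phenyl on the same carbonyl carbon would separate the presence of an aromatic ring from that of its nitrogens, and a saturated ring such as cyclohexyl would test whether aromaticity is needed. They also leave open what the isopropyl group contributes, which 1-methyl-1H-pyrazol-4-yl or the unsubstituted 1H-pyrazol-4-yl could show when set against compound 4.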